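The source may report more compounds than this note shows. Statements on the series, on what has been measured and on what is new or still open speak of the compounds shown alone.

In a functional assay on MCF7 cells (Homo sapiens) for antiproliferative activity, read by MTT assay, with a stated time of 48 h (a higher number here means a weaker inhibitor, a lower number a stronger inhibitor), compound 1 `Fc1ccc(-c2nn(-c3ccccc3)cc2-c2nc3cc(Br)ccc3[nH]2)cc1` gives 3210 nM and compound 2 `Clc1ccc(-c2nn(-c3ccccc3)cc2-c2nc3cc(Cl)ccc3[nH]2)cc1` gives 1170 nM as the lower of the two numbers, a gap beyond the usual scatter. That makes compound 2 the stronger inhibitor of this pair so far. Compound 3 `Clc1ccc(-c2nn(-c3ccccc3)cc2-c2nc3cc(Br)ccc3[nH]2)cc1` has one change from compound 2, namely bromo in place of chloro on an aromatic carbon and in words bromo in place of chloro on an aromatic carbon. Within the data shown here, no measured pair shows this swap alone, so there is no direct precedent for the size of the step in this assay to draw on. A step no larger than the scatter is expected, leaning slightly toward a higher number because compound 1 gives 3210 nM and also carries bromo, though it is not a clean comparison. The estimated change is a 1.4-fold higher number from compound 2 to compound 3 (0.14 log units; within the scatter) and so stays within the scatter. For compound 3 the expected value is 1600 nM with a likely range from 650 nM to 4000 nM as an estimate.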

Compound 3, half-maximal inhibitory concentration: 1920 nM
Beside the measured number, compound 3's estimate is 1.2-fold (0.08 log units) below it; the measured number falls inside the stated range.
By their numbers in this assay, from the lowest: compounds 2, 3 and 1 (each within the scatter of the next, the first and the last beyond it).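

Compound 3 differs from each of the other two compounds in one place only, so each halogen swap can be read alone in this assay. On the aromatic carbon of the fused two-ring system, bromo in place of chloro gives a 1.6-fold higher number from compound 2 to compound 3 (0.22 log units; within the scatter), and on the other halogen site, chloro in place of fluoro gives a 1.7-fold lower number from compound 1 to compound 3 (0.22 log units; within the scatter), so neither single swap stands clear of the scatter. Nothing measured here explains why these halogens behave so alike.

The compounds shown carry only chloro or bromo on this aromatic carbon, so it stays open whether a methoxy group, an amine or a carboxylic acid there would shift the number beyond the scatter. A plain hydrogen at this place is also untested among these compounds, so what either halogen adds over none remains unknown.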